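From butyl to 3-(methylsulfonyl)propyl on the shared core

A few compounds are considered here, and "the series" means these few. Any claim that something is new, unique, unknown or untested is made for them only; others in the source may bear on it.

Values in a physicochemical assay for lipophilicity, using the shake flask method, in phosphate buffer, measured as octanol-water partition, with a stated time of 24 h, at pH 7.4, tested at 100 uM (a higher number here means a more lipophilic compound, a lower number a more polar compound), so far
compound 1 (`Cc1cc(OCC(C)C)cc(C)c1-c1cccc(COc2ccc(OCC(=O)O)c(F)c2)c1`): "not determined" (no result reported)
compound 2 (`Cc1cc(O)cc(C)c1-c1cccc(COc2ccc(OCC(=O)O)c(F)c2)c1`): 2.37
compound 3 (`CCCCOc1cc(C)c(-c2cccc(COc3ccc(OCC(=O)O)c(F)c3)c2)c(C)c1`): "not determined" (no result reported)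

Compound 3 stands without a single number in this assay and compound 1 shares that gap, which leaves compound 2 at 2.37 as the only measured point. Compound 4 (`Cc1cc(OCCCS(C)(=O)=O)cc(C)c1-c1cccc(COc2ccc(OCC(=O)O)c(F)c2)c1`) awaits measurement. Relative to compound 3, methylsulfonyl takes the place of methyl on a saturated chain carbon, three bonds along the chain from an oxygen on an aromatic ring (counted: methylsulfonyl in place of methyl on a saturated chain carbon, three bonds along the chain from an oxygen on an aromatic ring). Among the compounds with values here, no measured step shows what such a change does. A downward step from compound 3 to compound 4, larger than the usual scatter, is nevertheless expected, though its size cannot be read from the data. The expectation rests on compound 2 at 2.37, and compound 4 is expected to fall near that value. Compound 4 is estimated at 2.3 (expected range 1.8 to 2.8).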

Compound 4, distribution coefficient: 1.81
Compound 4: middle estimate off by 0.49 log units, on the high side, and the stated range covers the measured number.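

In this assay, within the data shown here, 3-(methylsulfonyl)propyl in place of hydrogen on the oxygen on the aromatic ring gives a number 0.56 log units lower from compound 2 to compound 4 (beyond the scatter) and so provides the first readable step at this position, showing that this chain ends below the free hydroxyl compound rather than level with it. On these data alone, the change from butyl to 3-(methylsulfonyl)propyl itself cannot be read, as compound 3 has no single number here, so the size of that swap remains unknown. Nothing measured on hand explains the step from hydrogen to this chain.

Still open, as far as these compounds go, is where butyl and the branched chain of compound 1 would fall relative to compound 2 and compound 4. Also open, from the compounds shown here alone, is how 2-(methylsulfonyl)ethyl, a longer chain, or an amine in place of the methylsulfonyl would read at this oxygen.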